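Dithiocarbamate Benzamide Series: Piperazine Nitrogen Substituent Notes

A few compounds are considered here, and "the series" means these few. Any claim that something is new, unique, unknown or untested is made for them only; others in the source may bear on it.

Measured so far, with the read-out in a functional assay on HeLa cells (Homo sapiens) for antiproliferative activity, read by CCK-8 assay, with a stated time of 72 h, tested at 2 uM; on this read-out higher numbers stand for a stronger effect at the one concentration tested and lower numbers for a weaker effect:
compound 1 `Nc1ccccc1NC(=O)c1ccc(CSC(=S)N2CCN(C(c3ccccc3)c3ccccc3)CC2)cc1`, compound 1 gives 8%
compound 2 `Nc1ccccc1NC(=O)c1ccc(CSC(=S)N2CCN(c3ccccc3)CC2)cc1`, compound 2 gives 62.2%
compound 3 `Nc1ccccc1NC(=O)c1ccc(CSC(=S)N2CCCc3ccccc32)cc1`, compound 3 gives 26.1%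

Compound 2 stands highest of the three numbers in this assay. Its nearest neighbour is compound 3, whose number lies lower by a margin beyond the scatter, and the furthest is compound 1, whose number lies lower still, again beyond the scatter. No two of these compounds differ in one place only, so the numbers show only where each compound stands, not a single-point step.

Compound 4 `Nc1ccccc1NC(=O)c1ccc(CSC(=S)N2CCN(Cc3cccnc3)CC2)cc1` has not yet been measured in this assay. It differs from compound 2 as follows: (pyridin-3-yl)methyl in place of phenyl on an amine nitrogen in a ring.

For the measured compounds named here, since no step between measured compounds is available for this change, the expectation rests on the spread of the three numbers: every departure from the phenyl on the amine nitrogen in a ring seen so far sits lower than compound 2, which gives 62.2%. A downward step of moderate size is therefore expected, a number 27.2 percentage points lower from compound 2 to compound 4 (beyond the scatter), beyond the scatter but not to the floor set by compound 1. For compound 4 the estimate in this assay is 35%, expected to fall between 10% and 60%.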

Compound 4, a percentage reported as inhibition, at one concentration (the size of the read-out at that concentration, not a potency): 69.7%
For compound 4 the middle estimate is 34.7 percentage points below the measured one; measured number above the stated range.
By their numbers in this assay, from the lowest: compound 1; then compound 3; then compounds 2 and 4 (each within the scatter of the next).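

In this assay the change to (pyridin-3-yl)methyl in place of phenyl on the amine nitrogen in a ring gives a number 7.5 percentage points higher from compound 2 to compound 4 (within the scatter), so this position accepts the entering group, with its hetero atom and hydrogen-bond acceptor, without a loss beyond the usual scatter. The earlier numbers held only departures from compound 2 that stood lower, and compound 4 goes against that picture: a phenyl sitting directly on this nitrogen is not required for a high read-out at the one concentration tested, and a substituent on this nitrogen that carries a single aromatic ring is tolerated here, whereas compound 1, with two phenyl rings on its substituent, gives 8%. No measurement beyond this read-out bears on the result.

A plain benzyl group would help separate the contribution of the added carbon from that of the ring nitrogen, and pyridin-2-ylmethyl and pyridin-4-ylmethyl would test whether the placing of that nitrogen matters. Also open, as far as these compounds go, is how a simple methyl group, or a longer chain ending in an amine or a carboxylic acid, would read on the same nitrogen.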